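Lengthening a methoxy to an isobutoxy on the shared core

The source may hold more compounds than are shown below. What is called first, only, known or untested is meant among the compounds shown, and "the series" means these compounds.

Of the compounds shown here, two of a shared core have so far been measured in an assay on membranes from CHO cells for displacement of a labelled ligand from adenosine receptor A1 (Homo sapiens), read by scintillation counting, with a stated time of 60 min, tested at 1 uM; a lower number here means less inhibition, a higher number more inhibition at the concentration tested (going by the name of the read-out). Compound 1 `COC(=O)C1=C(C)NC(=O)NC1c1ccoc1` gives 8% there, and compound 2 `COC(=O)C1=C(C)NC(=O)NC1c1cccs1` gives 6%. Within the data shown here, the sole measured step between them is a number 2 percentage points lower from compound 1 to compound 2 (within the scatter), thiophen-2-yl in place of furan-3-yl on a saturated ring carbon. Compound 2 thus stands at the lower of the two numbers, but the gap to compound 1 lies within the scatter, so the two are not distinguishable.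

Compound 3 `CC1=C(C(=O)OCC(C)C)C(c2cccs2)NC(=O)N1` has not been measured. It differs from compound 2 in one place: isopropyl in place of hydrogen on a saturated chain carbon bound to an oxygen next to a carbonyl group, which, cut one bond further out, reads methoxy to isobutoxy. Among the measured compounds shown here, no measured step touches this position; the step from compound 1 to compound 2 changed only the ring on the saturated ring carbon and says nothing about the chain on the oxygen. Both measured numbers are small and close together. In this assay compound 3 is therefore expected to stay near compound 2, with an estimated step of a number 2 percentage points higher from compound 2 to compound 3 (within the scatter) that does not reach beyond the scatter. The estimate for compound 3 is 8%, with a range from -5% to 22%.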

Compound 3, a percentage reported as inhibition, at one concentration (the size of the read-out at that concentration, not a potency): 25%
Beside the measured number, compound 3's estimate is 17 percentage points below it, outside the stated range (above it).
By their numbers in this assay, from the lowest: compounds 2 and 1 (each within the scatter of the next); then compound 3.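

Among these compounds, of the two positions varied on the shared core, the chain on the oxygen is the one where a change moves the number in this assay beyond the scatter: methoxy to isobutoxy gives a number 19 percentage points higher from compound 2 to compound 3 (beyond the scatter) on the thiophen-2-yl compounds. The earlier change on the saturated ring carbon, with a number 2 percentage points lower from compound 1 to compound 2 (within the scatter), did not separate its two compounds, so a response at this site could not have been read from it. The compounds shown offer no measurement that accounts for the rise at this position.

On these data alone, with a single pair at this position, it stays open whether the number would follow chain length through ethoxy or a longer chain such as hexyloxy, or whether it depends on the branching of the isobutyl group, and how a benzyl ester or a carboxylic acid would read there. As far as these compounds go, it is also open whether isobutoxy would give a similar step with the furan-3-yl ring of compound 1, and what potency lies behind a reading taken at one concentration.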